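A methyl removed twice: one step measured, one expected

The source may hold more compounds than are shown below. What is called first, only, known or untested is meant among the compounds shown, and "the series" means these compounds.

Compound 1 `N/C(=N\NC(=S)N1CCCCCC1)c1ccccn1`: 88.7%
Compound 2 `Cc1ccnc(/C(N)=N/NC(=S)N2CCN(c3ccccn3)CC2)c1`: 85.6%
Compound 3 `Cc1cccc(/C(N)=N/NC(=S)N2CCCCCC2)n1`: 82.7%

In a functional assay on HeLa cells (Homo sapiens) for cytotoxicity, read by MTT assay, with a stated time of 72 h, tested at 100 uM (a higher number here means more inhibition of growth at the concentration tested, a lower number less inhibition of growth), compound 1 gives 88.7%, compound 2 gives 85.6% and compound 3 gives 82.7%; the three numbers all lie within the usual scatter of one another. Compound 3 and compound 1 differ in one place, (hydrogen in place of methyl on an aromatic carbon), and the step between them is a number 6 percentage points higher from compound 3 to compound 1 (within the scatter). Compound 4 `N/C(=N\NC(=S)N1CCN(c2ccccn2)CC1)c1ccccn1` is related to compound 2 by the same kind of change, (hydrogen in place of methyl on an aromatic carbon). The two changes are not the same: in compound 3 the methyl sits next to the ring nitrogen, in compound 2 opposite the ring nitrogen, while both are meta to a large group. How the cores of compound 2 and compound 3 differ is not broken down here.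

Compound 4 is expected to give 88% in this assay, within a range from 80% to 95%. This expectation rests on the measured step of a number 6 percentage points higher from compound 3 to compound 1 (within the scatter) having stayed within the scatter. The expected step is accordingly a number 2.4 percentage points higher from compound 2 to compound 4 (within the scatter).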

Compound 4, percent growth inhibition at one concentration: 85.6%
Beside the measured number, compound 4's estimate is 2.4 percentage points above it; the range from low to high includes it.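

In this assay, the step on taking away the methyl of the 4-methylpyridin-2-yl group is no change at the digits printed from compound 2 to compound 4 (within the scatter). Set beside the earlier step, the change carries across the two cores without a difference that can be told apart: the same change on two cores in this assay, a number 6 percentage points higher (within the scatter) from compound 3 to compound 1 and no change at the digits printed (within the scatter) from compound 2 to compound 4, 6 percentage points apart, within the scatter of two such steps. Within this small set, hydrogen in place of methyl on an aromatic carbon therefore gives no step beyond the scatter on either core, but that does not show that the methyl is without any effect or that the two places of the methyl are interchangeable, and two pairs set no rule for the series.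

The compounds shown leave open whether a different group at these places, such as an amine, a carboxylic acid or a longer chain, would give a step beyond the scatter.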